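Piperidin-1-yl to 1H-imidazol-1-yl at the Chain End

The compounds below may be only part of what the source reports. "The series", "measured", "known", "first", "only" and "open" are said of these compounds alone.

Measured compounds:
compound 1, `CC1(C)O[C@@H](CO)[C@H](Cn2cc(Cn3c4c(c5ccccc53)C(=O)c3c[n+]([O-])c5ccccc5c3C4=O)nn2)O1`: 680 nM
compound 2, `O=C1c2c[n+]([O-])c3ccccc3c2C(=O)c2c1c1ccccc1n2CCCCN1CCCCC1`: 610 nM

In a functional assay on MDA-MB-231 cells (Homo sapiens) for cytotoxicity, read by MTT assay, with a stated time of 72 h (on this read-out lower numbers stand for stronger inhibition and higher numbers for weaker inhibition), compound 2 gives 610 nM, and compound 1 gives 680 nM, a pair of numbers that sit within the usual scatter of each other, so neither stands apart. Compound 3, `O=C1c2c[n+]([O-])c3ccccc3c2C(=O)c2c1c1ccccc1n2CCCCn1ccnc1`, differs from compound 2 by 1H-imidazol-1-yl in place of piperidin-1-yl on a saturated chain carbon, four bonds along the chain from an aromatic nitrogen. For the measured compounds named here, no measured pair shows this change, so the expected step from compound 2 is small, a 1.2-fold higher number from compound 2 to compound 3 (0.09 log units; within the scatter), not clearly beyond the scatter in either direction. Compound 3 is therefore estimated at 750 nM, in the range 250 nM to 2200 nM.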

Compound 3, half-maximal inhibitory concentration: 210 nM
The estimate for compound 3 lay 3.6-fold (0.55 log units) above the measured number, outside the stated range (below it).
By their numbers in this assay, from the lowest: compound 3; then compounds 2 and 1 (each within the scatter of the next).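

In this assay, the end of this chain responds to the group it carries: 1H-imidazol-1-yl in place of piperidin-1-yl gives a 2.9-fold lower number from compound 2 to compound 3 (0.46 log units; beyond the scatter). Compound 1 and compound 2 differ in more than one place, so their numbers could not isolate this position. Nothing available here accounts for the lower number. Whether it is particular to 1H-imidazol-1-yl remains open, since the compounds shown do not tell how a morpholin-4-yl or a 1H-1,2,4-triazol-1-yl group would behave at the chain end. As far as these compounds go, what a longer or shorter chain would do with 1H-imidazol-1-yl also remains open.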